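The source may report more compounds than this note shows. Statements on the series, on what has been measured and on what is new or still open speak of the compounds shown alone.

Measured compounds:
- compound 1, `O=S1(=O)c2ccccc2CN1c1cccc(Oc2ccccc2)c1`: 174 nM
- compound 2, `Cc1ccccc1Oc1cc(F)cc(N2Cc3ccccc3S2(=O)=O)c1`: 44700 nM

Within the data shown here, in a functional assay on Flp-In T-REx293 cells for antagonist activity at Free fatty acid receptor 1 (Homo sapiens), read by calcium flux (a lower number here means a stronger inhibitor, a higher number a weaker inhibitor), compound 2 gives 44700 nM, the highest of the two numbers; the only neighbour, compound 1, gives 174 nM, a gap well beyond the scatter. Compound 3, `N#Cc1ccc(Oc2cc(F)cc(N3Cc4ccccc4S3(=O)=O)c2)cc1`, is not yet measured. Relative to compound 2 it carries 4-cyanophenyl in place of 2-methylphenyl on an oxygen on an aromatic ring. Among the measured compounds shown here, no step between two measured compounds isolates this change, so its size cannot be read from the series; the two values of compound 1 and compound 2 only show how wide the range of this assay runs across the set. Compound 3 is expected to give a lower number than compound 2, because compound 2 at 44700 nM leaves much room on the side of compound 1 at 174 nM; the expected step is a 3.7-fold lower number from compound 2 to compound 3 (0.57 log units; beyond the scatter). The estimate for compound 3 in this assay is 12000 nM, within 2500 nM to 50000 nM.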

Compound 3, half-maximal inhibitory concentration: 617 nM
Beside the measured number, compound 3's estimate is 19-fold (1.29 log units) above it; the whole stated range lies above it.
By their numbers in this assay, from the lowest: compound 1; then compound 3; then compound 2.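

In this assay the group on the oxygen on an aromatic ring proves to be a sensitive point in the series: exchanging 2-methylphenyl for 4-cyanophenyl gives a 72-fold lower number from compound 2 to compound 3 (1.86 log units; beyond the scatter) with the rest of the structure unchanged. Among these compounds, this is the first step between measured compounds that differ in one place, so the size of a change at this position can now be read directly. Among the compounds shown here, the single exchange removes the methyl and adds the nitrile at once, and nothing measured here explains the step.

On these data alone, it remains open how much of the step belongs to the loss of the methyl and how much to the gain of the nitrile; unsubstituted phenyl, 4-methylphenyl or 2-cyanophenyl on the same oxygen would separate the two. Also open, as far as these compounds go, is whether a carboxylic acid or an amine in place of the nitrile would keep a number this low.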